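Amide to urea on a shared indole-indazole core

A few compounds are considered here, and "the series" means these few. Any claim that something is new, unique, unknown or untested is made for them only; others in the source may bear on it.

Measured so far:
compound 1, `CN(C(=O)c1ccc(Br)cc1)c1ccc2[nH]c(-c3n[nH]c4ccccc34)cc2n1`: 3460 nM
compound 2, `CN(C(=O)c1ccco1)c1ccc2[nH]c(-c3n[nH]c4ccccc34)cc2n1`: 28200 nM

In a functional assay on SMMC-7721 cells (Homo sapiens) for antiproliferative activity, read by MTT assay, with a stated time of 72 h (on this read-out lower numbers stand for stronger inhibition and higher numbers for weaker inhibition), compound 2 gives 28200 nM, the higher of the two numbers; compound 1 gives 3460 nM. Among the compounds with values here, the only measured step is an 8.2-fold higher number from compound 1 to compound 2 (0.91 log units; beyond the scatter), which swaps one aromatic ring on the carbonyl carbon for another. Compound 3, `CN(C(=O)Nc1ccccc1)c1ccc2[nH]c(-c3n[nH]c4ccccc34)cc2n1`, is not yet measured. It differs from compound 2 by anilino in place of furan-2-yl on a carbonyl carbon, which brings a six-membered carbon-only ring back onto the carbonyl carbon, though joined through a nitrogen that carries a hydrogen rather than directly. That step bears on compound 3 only loosely, since a phenylcarbamoyl is neither of the two measured groups; still, the return of a benzene-type ring suggests the number should move back toward that of compound 1. Compound 3 is therefore expected to give 7000 nM, within 1500 nM to 30000 nM, an expected step of a 4.0-fold lower number from compound 2 to compound 3 (0.61 log units; beyond the scatter).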

Compound 3, half-maximal inhibitory concentration: 280 nM
Beside the measured number, compound 3's estimate is 25-fold (1.40 log units) above it; measured number outside the range, below it.
By their numbers in this assay, from the lowest: compound 3; then compound 1; then compound 2.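

In this assay, the group on the carbonyl carbon can shift the number much further than the two amides suggested: anilino gives a 100-fold lower number from compound 2 to compound 3 (2.00 log units; beyond the scatter), and set against 4-bromophenyl it gives a 12-fold lower number from compound 1 to compound 3 (1.09 log units; beyond the scatter). Compound 3 therefore falls well below both amides, so this change does more than restore a six-membered ring, and the anilino group also brings a hydrogen-bond donor that furan-2-yl lacks. Nothing available here explains why the number falls so far.

The compounds shown leave open whether the drop follows the nitrogen with its hydrogen or the ring attached to it, and a methylanilino or a cyclohexylamino group would help separate the two. Also open, as far as these compounds go, is how a bromine or a methoxy group on the anilino ring would move the number.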